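Chain extension on the lowest-reading member of the series

The source may hold more compounds than are shown below. What is called first, only, known or untested is meant among the compounds shown, and "the series" means these compounds.

Measured so far:
Compound 1, `CCCCCCCCCCCCCCc1nc(N2CCC2)nc(OC2CCC2)c1O`: 94%
Compound 2, `CCCCCCCCCCCCCCCCc1nc(N2CCC2)nc(OC2CCC2)c1O`: 103%
Compound 3, `CCCCCCCCCCCCCCc1nc(OC2CCC2)nc(N2CCC2)c1O`: 54%

In a functional assay on cells (Lymphocyte, Homo sapiens), read by a luciferase reporter and ATP content, with a stated time of 48 h, tested at 20 uM (a higher number here means a weaker effect of the compound at the concentration tested, a lower number a stronger effect), compound 3 stands lowest of the three numbers. Its nearest neighbour is compound 1 at 94%, a gap beyond the scatter, and compound 2 at 103% lies further off, also beyond the scatter. Among the compounds with values here, compound 3 and compound 1 share a chain of the same length and differ only in which ring substituent is joined through oxygen and which through nitrogen, and no single step between them is computed here; their two values alone mark the difference.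

Compound 4, `CCCCCCCCCCCCCCCCc1nc(OC2CCC2)nc(N2CCC2)c1O`, is not yet measured. It differs from compound 3 by ethyl in place of hydrogen on a saturated chain carbon, ten or more bonds along the chain from an aromatic carbon. Within the data shown here, the one measured step of the same kind, a number 9 percentage points higher from compound 1 to compound 2 (within the scatter), stayed within the scatter. On that basis the step of a number 6 percentage points higher from compound 3 to compound 4 (within the scatter) is expected to stay within the scatter as well, with no direction beyond it.

Compound 4 is therefore estimated at 60% in this assay, in the range 42% to 80%.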

Compound 4, a percentage reported as activity, at one concentration (the size of the read-out at that concentration, not a potency): 99%
The estimate for compound 4 lay 39 percentage points below the measured number; measured number outside the range, above it.
By their numbers in this assay, from the lowest: compound 3; then compounds 1, 4 and 2 (each within the scatter of the next).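

In this assay, ethyl in place of hydrogen on a saturated chain carbon, ten or more bonds along the chain from an aromatic carbon, gives a number 45 percentage points higher from compound 3 to compound 4 (beyond the scatter) on this core. The low reading of compound 3 therefore does not survive this extension of the chain, so the change cannot be treated as silent at this place. The same change does not carry the same result from one core to the other: the same change on two cores in this assay, a number 9 percentage points higher (within the scatter) from compound 1 to compound 2 and a number 45 percentage points higher (beyond the scatter) from compound 3 to compound 4, 36 percentage points apart, beyond the scatter of two such steps.

The compounds shown leave open how the reading on the core of compound 3 behaves at chain lengths between and beyond those of compound 3 and compound 4. Also open, as far as these compounds go, is whether a longer chain, or a chain ending in a carboxylic acid or an amine, would keep the reading of compound 3 or lose it.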